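Hydroxy in place of hydrogen on the anilino ring

The compounds below may be only part of what the source reports. "The series", "measured", "known", "first", "only" and "open" are said of these compounds alone.

Measured so far:
Compound 1 `Fc1cccc(-c2nc(Nc3ccccc3)c3cc(F)ccc3n2)c1` gives 49700 nM in a functional assay on MCF7 cells (Homo sapiens) for cytotoxicity, read by MTT assay, with a stated time of 48 h; on this read-out lower numbers stand for stronger inhibition and higher numbers for weaker inhibition.
Compound 2 `Fc1cccc(-c2nc(Nc3ccc(Br)cc3)c3cc(F)ccc3n2)c1` gives > 50000 nM in this assay, a limit of the assay rather than a number.
Compound 3 `Fc1cccc(-c2nc(Nc3ccccc3Br)c3cc(F)ccc3n2)c1` gives > 50000 nM in this assay, likewise a limit.

Compound 1 stands as the only number shown; the two other values are limits. The two measured steps from compound 1 both set bromo in place of hydrogen on an aromatic carbon: a number no lower from compound 1 to compound 2 (the limit leaves the size open) and a number no lower from compound 1 to compound 3 (the limit leaves the size open). Between the two bromo compounds a step that the two limits leave unreadable from compound 2 to compound 3 cannot be read, because both sit at the limit of > 50000 nM in this assay, at which 2 of the 3 values shown sit. Neither step tells anything about a hydroxy group.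

Compound 4 `Oc1ccc(Nc2nc(-c3cccc(F)c3)nc3ccc(F)cc23)cc1` differs from compound 1 by hydroxy in place of hydrogen on an aromatic carbon. Among the compounds with values here, no measured step bears directly on this change, and the numbers known all lie at or near the limit. No step beyond the scatter is therefore expected; the estimated step is a 1.1-fold lower number from compound 1 to compound 4 (0.04 log units; within the scatter). Compound 4 is expected to give 45000 nM in this assay, with a range from 15000 nM to 150000 nM, and a fair chance that only a limit is reported.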

Compound 4, half-maximal inhibitory concentration: > 50000 nM
Compound 4: only a limit was reported; the forecaster's own chance of this, stated with the estimate: 50%; middle value at least 1.1-fold (0.04 log units) from the limit.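

Hydroxy in place of hydrogen, on an aromatic carbon para to a large group, gives a number no lower from compound 1 to compound 4 (the limit leaves the size open), so this donor and acceptor group, like bromo, yields no number lower than that of the unsubstituted anilino ring of compound 1. Compound 4 reads > 50000 nM in this assay, a limit of the assay and not a number. The steps among compound 2, compound 3 and compound 4 cannot be read, because all three sit at the same limit: the limit of > 50000 nM in this assay, at which 3 of the 4 values shown sit.

Going by these compounds, whether any group on this ring can bring the number down stays open; an amine or a carboxylic acid at the same place would test this. On these data alone, how far compound 2, compound 3 and compound 4 lie beyond the limit, and whether they differ from one another, also stays open.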